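A methoxy-rich swap on a growth-inhibiting compound

The compounds below may be only part of what the source reports. "The series", "measured", "known", "first", "only" and "open" are said of these compounds alone.

Compound 1 (`COc1ccc(C(=O)N2N=C(c3ccccc3)CC2c2cn(C)c3ccccc23)cn1`): 3130 nM
Compound 2 (`Cn1cc(C2CC(c3ccc(F)cc3)=NN2C(=O)c2cccnc2)c2cc(Br)ccc21`): 480 nM

In a functional assay on HepG2 cells (Homo sapiens) for inhibition, read by MTT assay, with a stated time of 48 h (on this read-out higher numbers stand for weaker inhibition of growth and lower numbers for stronger inhibition of growth), compound 2 holds the lower of the two numbers, and its gap to compound 1 lies beyond the scatter. Compound 3 (`COc1ccc(C2=NN(C(=O)c3cccnc3)C(c3cn(C)c4ccc(Br)cc34)C2)cc1OC`) has not been measured. It carries 3,4-dimethoxyphenyl in place of 4-fluorophenyl on a carbon with a double bond to nitrogen. Among the compounds with values here, no measured pair shows this change alone, so its effect remains uncertain. A modest weakening of growth inhibition is expected (a 1.9-fold higher number from compound 2 to compound 3 (0.27 log units; within the scatter)). Compound 3 is estimated at 900 nM (expected range 250 nM to 3200 nM).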

Compound 3, concentration for 50% growth inhibition: 2450 nM
The estimate for compound 3 lay 2.7-fold (0.43 log units) below the measured number, within the range that was stated.
By their numbers in this assay, from the lowest: compound 2; then compounds 3 and 1 (each within the scatter of the next).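

In this assay, the carbon with a double bond to nitrogen proves sensitive to the group it carries: 3,4-dimethoxyphenyl in place of 4-fluorophenyl gives a 5.1-fold higher number from compound 2 to compound 3 (0.71 log units; beyond the scatter), a weakening of growth inhibition beyond the scatter. Within the data shown here, this is the first change that can be read alone, since compound 1 differs from compound 2 in more than one place. Nothing measured here explains this step. The compounds shown leave open whether both methoxy groups are needed for this weakening, as 4-methoxyphenyl would test. They also leave open how an amine on this phenyl ring would fare.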